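This account rests on a few compounds, and the source may have more. Where it says the series, first, only, none or still open, it means among the compounds named here.

Measured in a functional assay on SH-SY5Y cells (Homo sapiens) for inhibition, read by sulforhodamine B assay; on this read-out lower numbers stand for stronger inhibition and higher numbers for weaker inhibition:
- compound 1 `COC(=O)CC/C(C)=C/Cc1c(OC)c(C)c2c(c1OCC#CCN1CCN(c3ccc(C#N)cc3)CC1)C(=O)OC2`: 37800 nM
- compound 2 `COC(=O)CC/C(C)=C/Cc1c(OC)c(C)c2c(c1OCC#CCN1CCN(c3ccccc3F)CC1)C(=O)OC2`: 35800 nM
- compound 3 `COC(=O)CC/C(C)=C/Cc1c(OC)c(C)c2c(c1OCC#CCN1CCN(Cc3ccc(Cl)cc3)CC1)C(=O)OC2`: 31200 nM

Compound 3 cannot be separated from the other two measured compounds, as the two steps that reach it show: a 1.1-fold lower number from compound 2 to compound 3 (0.06 log units; within the scatter) and a 1.2-fold lower number from compound 1 to compound 3 (0.08 log units; within the scatter). Compound 4 `COC(=O)CC/C(C)=C/Cc1c(OC)c(C)c2c(c1OCC#CCN1CCN(c3ccccc3OC)CC1)C(=O)OC2` has not yet been measured. It keeps the shared core and carries 2-methoxyphenyl in place of 4-chlorobenzyl on an amine nitrogen in a ring.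

Going by the values given here, all the measured steps bear on this change, since each swaps the group at that same nitrogen. The remaining one is a 1.1-fold lower number from compound 1 to compound 2 (0.02 log units; within the scatter). Like the two above, it stays small, although these three compounds are the only evidence. The step expected in this assay is therefore none beyond the scatter, and the estimate is a 1.1-fold higher number from compound 3 to compound 4 (0.04 log units; within the scatter).

For compound 4 the estimated value is 34000 nM, with an expected range of 21000 nM to 52000 nM.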

Compound 4, half-maximal inhibitory concentration: 43600 nM
Estimate against measurement, compound 4: 1.3-fold (0.11 log units) below; the range from low to high includes it.
By their numbers in this assay, from the lowest: compounds 3, 2, 1 and 4 (each within the scatter of the next).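

The 2-methoxyphenyl group brings an oxygen and a hydrogen-bond acceptor that 4-chlorobenzyl lacks, yet in this assay this swap stays within the scatter (a 1.4-fold higher number from compound 3 to compound 4 (0.15 log units; within the scatter)). Methoxy in place of fluoro on an aromatic carbon (a 1.2-fold higher number from compound 2 to compound 4 (0.09 log units; within the scatter)) and 2-methoxyphenyl in place of 4-cyanophenyl (a 1.2-fold higher number from compound 1 to compound 4 (0.06 log units; within the scatter)) also stay within it, so all four groups on this amine nitrogen remain inseparable, with an oxygen-bearing group now among them. Nothing available explains this flat response.

From the compounds shown here alone, it remains open whether a carboxylic acid or a simple amine on the aromatic ring, or a longer chain on this nitrogen, would move the number beyond the scatter. Also open, going by these compounds, is whether a change elsewhere, such as a carboxylic acid in place of the methyl ester, would do so.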